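Propyl to Benzyl Ester Change on Three Compounds at the Limit

A few compounds are considered here, and "the series" means these few. Any claim that something is new, unique, unknown or untested is made for them only; others in the source may bear on it.

Compound 1, `CCCOC(=O)N1N=C(c2cccc(OC)c2)CC1c1cc(OC)c(OC)c(OC)c1`: in a functional assay on A549 cells (Homo sapiens) for antiproliferative activity, read by MTT assay, with a stated time of 48 h (a lower number here means a stronger inhibitor of growth, a higher number a weaker inhibitor of growth), compound 1 gives > 10000 nM, which is a limit of the assay and not a number.
Compound 2, `COc1cccc(C2=NN(C(=O)OCc3ccccc3)C(c3cc(OC)c(OC)c(OC)c3)C2)c1`: in this assay compound 2 gives > 10000 nM, again a limit rather than a number.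
Compound 3, `CCCOC(=O)N1N=C(c2ccc(OC)cc2)CC1c1cc(OC)c(OC)c(OC)c1`: in this assay compound 3 gives > 10000 nM, also a limit and not a number.

Compound 2 differs from compound 1 by phenyl in place of ethyl on a saturated chain carbon bound to an oxygen next to a carbonyl group. Compound 3 differs from compound 1 by 4-methoxyphenyl in place of 3-methoxyphenyl on a carbon with a double bond to nitrogen. The steps a step that the two limits leave unreadable from compound 1 to compound 2 and a step that the two limits leave unreadable from compound 1 to compound 3 cannot be sized because of the limit of > 10000 nM in this assay, at which 3 of the 3 values shown sit.

Compound 4, `COc1ccc(C2=NN(C(=O)OCc3ccccc3)C(c3cc(OC)c(OC)c(OC)c3)C2)cc1`, has not yet been measured. It differs from compound 3 by phenyl in place of ethyl on a saturated chain carbon bound to an oxygen next to a carbonyl group, the same change, at the same place, as that from compound 1 to compound 2. For compound 4 the expected step is a step that the limit leaves unreadable from compound 3 to compound 4, and this expectation rests on the step that the two limits leave unreadable from compound 1 to compound 2 together with the limit of > 10000 nM in this assay, at which 3 of the 3 values shown sit. Compound 4 is therefore expected to give about 15000 nM, between 5000 nM and 50000 nM, and most likely to be reported once more only as a limit.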

Compound 4, concentration for 50% growth inhibition: > 10000 nM
Compound 4 gave a limit, no number; the forecaster's own chance of this, stated with the estimate: 80%; the middle value is on the limit's open side.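

Compound 4, like compound 1, compound 2 and compound 3, gives only a limit and not a number, so the steps from compound 3 to compound 4 and from compound 2 to compound 4 cannot be read: the limit of > 10000 nM in this assay, at which 4 of the 4 values shown sit.

The compounds shown leave open whether exchanging propoxycarbonyl for benzyloxycarbonyl, or 3-methoxyphenyl for 4-methoxyphenyl, changes growth inhibition at all.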